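The source may report more compounds than this note shows. Statements on the series, on what has been measured and on what is new or still open speak of the compounds shown alone.

Of the compounds shown here, three built on one shared core have been measured in a physicochemical assay for solubility, measured as kinetic solubility, at pH 2; a lower number here means a less soluble compound, a higher number a more soluble compound. Compound 1 `CC(C)C(/C=C1\CCNC1=O)c1ccc(-c2ccc3cccc(F)c3c2)[nH]c1=O` gives 23600 nM, compound 2 `CC(C)C(c1noc(=O)[nH]1)c1ccc(-c2ccc3cccc(F)c3c2)[nH]c1=O` gives 23200 nM, and compound 3 `CC(C)C(Nc1nnc[nH]1)c1ccc(-c2ccc3cccc(F)c3c2)[nH]c1=O` gives 39000 nM. Compound 3 holds the highest of the three numbers, but the gaps to both others are within the usual scatter: a 1.7-fold higher number from compound 1 to compound 3 (0.22 log units; within the scatter), and a 1.7-fold higher number from compound 2 to compound 3 (0.23 log units; within the scatter). Compound 4 `Cc1c[nH]c(C(c2ccc(-c3ccc4cccc(F)c4c3)[nH]c2=O)C(C)C)n1` changes the same position once more: 4-methyl-1H-imidazol-2-yl in place of (4H-1,2,4-triazol-3-yl)amino on a saturated chain carbon bound to an aromatic carbon and a saturated chain carbon. The two earlier exchanges at this position, a 1.0-fold lower number from compound 1 to compound 2 (0.01 log units; within the scatter) and a 1.7-fold higher number from compound 2 to compound 3 (0.23 log units; within the scatter), each stayed within the scatter, so no step beyond the scatter is expected here either, with a 1.3-fold lower number from compound 3 to compound 4 (0.11 log units; within the scatter) as the estimated step. For compound 4 the expected value in this assay is 30000 nM, within a range from 12000 nM to 75000 nM.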

Compound 4, solubility: 6300 nM
Compound 4: the middle estimate sits 4.8-fold (0.68 log units) above what was measured, outside the stated range (below it).
By their numbers in this assay, from the lowest: compound 4; then compounds 2, 1 and 3 (each within the scatter of the next).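

This position can matter in this assay: the three earlier groups stayed within the scatter of one another, whereas 4-methyl-1H-imidazol-2-yl gives a 6.2-fold lower number from compound 3 to compound 4 (0.79 log units; beyond the scatter), a 3.7-fold lower number from compound 2 to compound 4 (0.57 log units; beyond the scatter) and a 3.7-fold lower number from compound 1 to compound 4 (0.57 log units; beyond the scatter). Compound 4 therefore stands lowest of the four, with each of its steps beyond the scatter. No measurement at hand offers an explanation for this step.

The compounds shown do not separate the contribution of the imidazole ring from that of its methyl group. Also open, as far as these compounds go, is how an unsubstituted imidazole, an amine or a carboxylic acid would read at this position.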